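The compounds below may be only part of what the source reports. "The series", "measured", "known", "first", "only" and "open" are said of these compounds alone.

Measured so far in a functional assay on A549 cells (Homo sapiens) for antiproliferative activity, read by trypan blue exclusion, with a stated time of 72 h, tested at 20 uM; on this read-out lower numbers stand for less inhibition and higher numbers for more inhibition at the one concentration tested (going by the name of the read-out):
compound 1 `O=C1NC(=O)N(Cc2ccccc2)/C1=C/c1ccccc1` gives 2.9%
compound 2 `CCCCN1C(=O)NC(=O)/C1=C\c1ccccc1` gives 6.8%
compound 3 `CCCCN1C(=O)NC(=O)/C1=C/c1ccccc1` gives 18%

Compound 2 stands second highest of the three numbers. Its nearest neighbour is compound 1: the step of a number 3.9 percentage points higher from compound 1 to compound 2 (within the scatter) lies within the scatter, so nothing separates the two. The step of a number 11.2 percentage points higher from compound 2 to compound 3 (beyond the scatter) is beyond the scatter, a modest rise, and rests on (the fact that compounds 2 and 3 differ only in the configuration as drawn).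

Compound 4 `CCCCN1C(=O)NC(=O)/C1=C\c1ccc(Cl)cc1` has not yet been measured in this assay. It differs from compound 2 by chloro in place of hydrogen on an aromatic carbon. Neither measured step bears on this change: one concerns the group on the amide-type nitrogen in the ring, the other only the configuration as drawn. Among the measured compounds shown here, no step that touches the aromatic ring has been measured, so there is no basis to expect a change beyond the scatter in this assay. The step expected is a number 3.2 percentage points higher from compound 2 to compound 4 (within the scatter), i.e. essentially none. Compound 4 is therefore estimated at 10%, in the range 0% to 25%.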

Compound 4, a percentage reported as inhibition, at one concentration (the size of the read-out at that concentration, not a potency): 29%
For compound 4 the middle estimate is 19 percentage points below the measured one; measured number above the stated range.
By their numbers in this assay, from the lowest: compounds 1 and 2 (each within the scatter of the next); then compound 3; then compound 4.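

In this assay the aromatic ring proves to be a place where one small change moves the number: chloro in place of hydrogen on an aromatic carbon, para to a large group, gives a number 22.2 percentage points higher from compound 2 to compound 4 (beyond the scatter). Among the compounds shown here, the earlier steps touched only the group on the amide-type nitrogen and the configuration as drawn, so this is the first sign that the series responds at the aromatic ring, and one added heavy atom is enough to show it. Nothing at hand speaks to what lies behind this step.

From the compounds shown here alone, whether the rise belongs to chloro itself or would also follow from fluoro, methoxy or a carboxylic acid at this place remains open. Equally open, going by these compounds, is whether chloro carries the same step on the cores of compound 1 and compound 3.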